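Methoxy to ethoxy on compound 3

A few compounds are considered here, and "the series" means these few. Any claim that something is new, unique, unknown or untested is made for them only; others in the source may bear on it.

In a toxicity assay on microsomes from liver (Homo sapiens) for metabolic stability, read by LC-MS, using NADPH, tested at 1 uM (on this read-out higher numbers stand for fast clearance and lower numbers for slow clearance), compound 3 `COc1ccc(-c2nc(C(F)(F)F)sc2N2CCN(C(=O)Cn3nc(C)nc3C)[C@H](C)C2)cn1` gives < 10 mL.min-1.g-1 as a limit, not a number. Compound 1 `COc1ncc(-c2nc(C(F)(F)F)sc2N2CCN(C(=O)Cn3nc(C)nc3C)[C@H](C)C2)cn1` gives < 10 mL.min-1.g-1 as a limit too. Compound 2 `Cc1nc(C)n(CC(=O)N2CCN(c3sc(C(F)(F)F)nc3-c3cnc(N4CCCC4)nc3)C[C@H]2C)n1` gives 338 mL.min-1.g-1 as a measured number. Compound 4 `CCOc1ccc(-c2nc(C(F)(F)F)sc2N2CCN(C(=O)Cn3nc(C)nc3C)[C@H](C)C2)cn1` carries methyl in place of hydrogen on a saturated chain carbon bound to an oxygen on an aromatic ring in going from methoxy to ethoxy, with methyl in place of hydrogen on a saturated chain carbon bound to an oxygen on an aromatic ring. For the measured compounds named here, no measured step alters that chain alone. Pyrrolidin-1-yl in place of methoxy gave an at least 33-fold higher number from compound 1 to compound 2 (1.52 log units; beyond the scatter) as one large step, and an at least 33-fold lower number from compound 2 to compound 3 (1.52 log units; beyond the scatter) is the other. Between the two methoxy compounds lies a step that the two limits leave unreadable from compound 1 to compound 3 with no size to read. Only a small upward move is therefore expected, estimated as an at least 1.2-fold higher number from compound 3 to compound 4 (0.07 log units; that floor lies within the scatter) in this assay here. Compound 4 is expected at 12 mL.min-1.g-1 with a range from 5 mL.min-1.g-1 to 40 mL.min-1.g-1 on this estimate.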

Compound 4, intrinsic clearance in microsomes: 66 mL.min-1.g-1
Estimate against measurement, compound 4: 5.5-fold (0.74 log units) below, outside the stated range (above it).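

In this assay, for the compounds shown here, one added methyl on a saturated chain carbon bound to an oxygen on an aromatic ring gives an at least 6.6-fold higher number from compound 3 to compound 4 (0.81 log units; beyond the scatter) and so shows that this chain, unchanged among the earlier compounds, does move the read-out. The ethoxy compound also shows an at least 6.6-fold higher number from compound 1 to compound 4 (0.81 log units; beyond the scatter) and a 5.1-fold lower number from compound 2 to compound 4 (0.71 log units; beyond the scatter) which leaves it above the methoxy compounds and under the pyrrolidin-1-yl compound. The full size of the rise cannot be read, as the methoxy end is a limit: the limit of < 10 mL.min-1.g-1 in this assay, at which 2 of the 4 values shown sit.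

From the compounds shown here alone, whether a propoxy or isopropoxy group would raise the number further stays open. So does whether 2-ethoxypyrimidin-5-yl would behave like 6-ethoxypyridin-3-yl.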